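Moving the Fluorine on the Anilide of Compound 1

A few compounds are considered here, and "the series" means these few. Any claim that something is new, unique, unknown or untested is made for them only; others in the source may bear on it.

Measured compounds:
compound 1, `CN1C[C@H](C(=O)Nc2ccc(F)cc2)[C@@H](c2ccc(/C=C/C(=O)Nc3ccccc3N)cc2)C1`, giving 5 mL/min/kg
compound 2, `CN1C[C@H](C(=O)Nc2ccc(C#N)cc2)[C@@H](c2ccc(/C=C/C(=O)Nc3ccccc3N)cc2)C1`, giving 1 mL/min/kg

In an in vitro ADME assay on microsomes from liver (Homo sapiens) for pharmacokinetics, read by LC-MS, with a stated time of 10 min, tested at 1 uM (on this read-out lower numbers stand for slow clearance and higher numbers for fast clearance), compound 1 gives 5 mL/min/kg, the highest of the two numbers measured. Its nearest neighbour is compound 2, with 1 mL/min/kg; the step of a 5.0-fold lower number from compound 1 to compound 2 (0.70 log units; beyond the scatter) came from putting cyano in place of fluoro on an aromatic carbon.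

Compound 3, `CN1C[C@H](C(=O)Nc2ccccc2F)[C@@H](c2ccc(/C=C/C(=O)Nc3ccccc3N)cc2)C1`, has not been measured in this assay. It differs from compound 1 by 2-fluorophenyl in place of 4-fluorophenyl on an amide-type nitrogen; the fluorine stays, and only its place on the ring changes. Going by the values given here, the one measured step, from compound 1 to compound 2, swapped the group itself and so says nothing about moving a fluorine around the ring. Among the compounds with values here, no measured pair bears on the change in hand, so the expectation is for no step beyond the scatter.

Compound 3 is therefore estimated at 5 mL/min/kg, with a range from 2 mL/min/kg to 12 mL/min/kg, which means an expected step of no change at the digits printed from compound 1 to compound 3 (within the scatter).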

Compound 3, clearance: 10 mL/min/kg
Beside the measured number, compound 3's estimate is 2.0-fold (0.30 log units) below it; the measured number falls inside the stated range.
By their numbers in this assay, from the lowest: compound 2; then compounds 1 and 3 (each within the scatter of the next).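

In this assay, the place of the fluorine now has a reading of its own: 2-fluorophenyl in place of 4-fluorophenyl on the amide-type nitrogen gives a 2.0-fold higher number from compound 1 to compound 3 (0.30 log units; within the scatter), so this read-out does not tell compound 1 and compound 3 apart. The larger step lies with the group itself, as 2-fluorophenyl in place of 4-cyanophenyl gives a 10-fold higher number from compound 2 to compound 3 (1.00 log units; beyond the scatter), beyond the scatter. Across these three compounds, then, the two fluorophenyl compounds stay together and compound 2 alone stands apart, with no compound going against that reading, and nothing at hand explains these numbers.

The compounds shown leave open how an amine, a carboxylic acid or a methoxy group would read on this ring, where only fluoro and cyano appear so far. They also leave open whether the place on the ring would count for as little with cyano as it does with fluoro, and whether compound 3 and compound 1 would stay within the scatter of each other in other substituted anilides on the same core.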